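The compounds below may be only part of what the source reports. "The series", "measured", "known", "first", "only" and "open" are said of these compounds alone.

Working notes on the series. The shared core is that of compound 1 `Fc1cc2nc(-c3cccnc3)n(C3CC3)c2cc1F`, which in an assay on V79 cells for inhibition of cytochrome P450 11B2, mitochondrial (Homo sapiens), read by HTRF, with a stated time of 1 h (on this read-out lower numbers stand for stronger inhibition and higher numbers for weaker inhibition), gives 2.1 nM. Compound 2 `CS(=O)(=O)c1ccc2c(c1)nc(-c1cccnc1)n2C1CC1` returns only a limit in this assay, > 1000 nM, which is the limit of > 1000 nM in this assay, at which 1 of the 3 values shown sits. Going by the values given here, compound 3 `N#Cc1cc2c(cc1F)nc(-c1cccnc1)n2C1CC1` gives 0.6 nM in this assay, the lowest of the two numbers reported as numbers, with compound 1 nearest; the one measured step in the set, a 3.5-fold lower number from compound 1 to compound 3 (0.54 log units; beyond the scatter), counts as modest.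

Compound 4 `Fc1ccc2c(c1)nc(-c1cccnc1)n2C1CC1` differs from compound 3 by hydrogen in place of cyano on an aromatic carbon. Among the compounds with values here, no measured step swaps a cyano group for hydrogen, so the only step that bears on the change is a 3.5-fold lower number from compound 1 to compound 3 (0.54 log units; beyond the scatter), where cyano entered on the same aromatic carbon and gave a modest gain. Losing the cyano group entirely is expected to undo roughly that gain, giving a modest rise in the number in this assay, a 4.2-fold higher number from compound 3 to compound 4 (0.62 log units; beyond the scatter). The estimate for compound 4 in this assay is 2.5 nM, expected to fall between 1 nM and 7 nM.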

Compound 4, half-maximal inhibitory concentration: 28 nM
Compound 4: middle estimate off by 11-fold (1.05 log units), on the low side, outside the stated range (above it).
By their numbers in this assay, from the lowest: compound 3; then compound 1; then compound 4. At a limit, above all of these: compound 2.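

In this assay, the loss of the cyano group costs far more than its entry in place of fluoro gained, with a 47-fold higher number from compound 3 to compound 4 (1.67 log units; beyond the scatter) set against a 3.5-fold lower number from compound 1 to compound 3 (0.54 log units; beyond the scatter), so the two changes at this aromatic carbon cannot be read as one scale of equal steps. Hydrogen at this carbon, ortho to a fluoro group, also falls well short of fluoro, with a 13-fold higher number from compound 1 to compound 4 (1.12 log units; beyond the scatter), so among these three compounds the larger difference lies between hydrogen and either group rather than between fluoro and cyano. The step with fluoro in place of methylsulfonyl, an at least 35-fold lower number from compound 2 to compound 4 (1.55 log units; beyond the scatter), starts from a limit rather than a number, the one held by compound 2: the limit of > 1000 nM in this assay, at which 1 of the 4 values shown sits.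

As far as these compounds go, whether chloro, methyl or methoxy on this carbon would match fluoro or cyano remains open. From the compounds shown here alone, how an amine or a carboxylic acid would fare at the same place is equally open.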